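From a tert-butoxy side chain to cyclohexyl

A few compounds are considered here, and "the series" means these few. Any claim that something is new, unique, unknown or untested is made for them only; others in the source may bear on it.

Of the compounds shown here, three sharing one core have been measured in an ADME assay on Caco-2 cells (Homo sapiens) for permeability, read by LC-MS, in the apical to basolateral direction, with a stated time of 60 min, at pH 6.5; a lower number here means that the compound crosses the layer more slowly, a higher number that the compound crosses the layer faster. Compound 1 `O=C(NCc1cc(Cl)ccc1-n1cnnn1)[C@@H]1C[C@@H]2C[C@@H]2N1C(=O)[C@H](O)CC1CC1` gives 3.6 10^-6 cm/s, compound 2 `O=C(NCc1cc(Cl)ccc1-n1cnnn1)[C@@H]1C[C@@H]2C[C@@H]2N1C(=O)[C@H](O)Cn1cccn1` gives 0.45 10^-6 cm/s, and compound 3 `CC(C)(C)OC[C@@H](O)C(=O)N1[C@H](C(=O)NCc2cc(Cl)ccc2-n2cnnn2)C[C@@H]2C[C@@H]21` gives 4.5 10^-6 cm/s. Compound 3 shares the top of this small set, as a 1.3-fold higher number from compound 1 to compound 3 (0.10 log units; within the scatter) is no real separation, whereas a 10-fold higher number from compound 2 to compound 3 (1.00 log units; beyond the scatter) sets it clear.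

Compound 4 `O=C(NCc1cc(Cl)ccc1-n1cnnn1)[C@@H]1C[C@@H]2C[C@@H]2N1C(=O)[C@H](O)C1CCCCC1` differs on a saturated chain carbon bound to a carbonyl carbon and an oxygen on a saturated carbon: cyclohexyl in place of (tert-butoxy)methyl on a saturated chain carbon bound to a carbonyl carbon and an oxygen on a saturated carbon. Among the measured compounds shown here, no measured step makes this exact replacement, so the evidence is indirect. The two steps beyond the scatter both involve 1H-pyrazol-1-yl, which compound 4 does not carry: an 8.0-fold lower number from compound 1 to compound 2 (0.90 log units; beyond the scatter) brings it in, and a 10-fold higher number from compound 2 to compound 3 (1.00 log units; beyond the scatter) takes it out. The closer guide is the exchange of cyclopropyl for tert-butoxy, which gave a 1.3-fold higher number from compound 1 to compound 3 (0.10 log units; within the scatter). The entering cyclohexyl is, like the cyclopropyl of compound 1, a ring of carbon only. In this assay no step beyond the scatter is therefore expected, and the estimated move is a 1.1-fold higher number from compound 3 to compound 4 (0.05 log units; within the scatter). The estimate for compound 4 is 5 10^-6 cm/s, with an expected range from 2.2 10^-6 cm/s to 11 10^-6 cm/s.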

Compound 4, apparent permeability: 16 10^-6 cm/s
The estimate for compound 4 lay 3.2-fold (0.51 log units) below the measured number, outside the stated range (above it).
By their numbers in this assay, from the lowest: compound 2; then compounds 1 and 3 (each within the scatter of the next); then compound 4.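

Among the compounds shown here, on a saturated chain carbon bound to a carbonyl carbon and an oxygen on a saturated carbon, the earlier steps beyond the scatter all brought in or took out 1H-pyrazol-1-yl, but in this assay cyclohexyl also gives such steps without that group, with a 3.6-fold higher number from compound 3 to compound 4 (0.55 log units; beyond the scatter) and a 4.4-fold higher number from compound 1 to compound 4 (0.65 log units; beyond the scatter). The first of these exchanges (tert-butoxy)methyl for cyclohexyl at an equal count of 6 heavy atoms, so the count of heavy atoms alone does not set the number at this position, and the entering group's ring of carbon only did not place it level with the cyclopropylmethyl compound. The span of the set also widens, to a 36-fold higher number from compound 2 to compound 4 (1.55 log units; beyond the scatter), and compound 4 now stands clear at the top, beyond the scatter from each of the other three.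

Nothing available explains why cyclohexyl reads higher than the other groups at this position. The compounds shown also leave open whether the higher number belongs to the six-membered ring itself or to the direct attachment of a ring to this carbon, and how an amine or a carboxylic acid on the same carbon would read in this assay.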